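Methyl on the fused ring: compound 2 to compound 3

The source may report more compounds than this note shows. Statements on the series, on what has been measured and on what is new or still open speak of the compounds shown alone.

Compound 1 `Cc1nc(C)c(COc2ccccc2C(=O)O)nc1C` and compound 2 `Cc1nc(C)c(COc2ccc3ccc(=O)oc3c2)nc1C` share a core. In a functional assay on ECV-304 cells (Homo sapiens), read by MTT assay, with stated times of 24 h and 12 h, tested at 25 uM (a higher number here means a stronger effect of the compound at the concentration tested, a lower number a weaker effect), compound 1 gives 17.4%, and compound 2 gives 42%. Compound 2 stands highest of the two numbers, and its gap to compound 1 lies beyond the scatter. Compound 3 `Cc1nc(C)c(COc2ccc3c(C)cc(=O)oc3c2)nc1C` is not yet measured; it differs from compound 2 by methyl in place of hydrogen on an aromatic carbon. Within the data shown here, no measured pair shows this change, so the step is unknown. A small step is expected in this assay, probably none beyond the scatter, meaning a number 3 percentage points higher from compound 2 to compound 3 (within the scatter). Compound 3 is estimated at 45%, between 25% and 65%.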

Compound 3, a percentage reported as activity, at one concentration (the size of the read-out at that concentration, not a potency): 21%
The estimate for compound 3 lay 24 percentage points above the measured number; measured number outside the range, below it.
By their numbers in this assay, from the lowest: compounds 1 and 3 (each within the scatter of the next); then compound 2.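

Under this assay methyl in place of hydrogen on this aromatic carbon, opposite the ring oxygen, gives a number 21 percentage points lower from compound 2 to compound 3 (beyond the scatter) and so this position is sensitive to even this small change. The earlier compounds shown here gave no view of this place, since they differ from each other in more than one part. No available evidence bears on the reason for the drop.

Still open, on these data alone, is whether the loss follows methyl alone or any group at this carbon, such as an amine, a methoxy group or a longer chain. Also open, as far as these compounds go, is whether methyl on another carbon of the fused system gives a similar step.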